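The compounds below may be only part of what the source reports. "The series", "measured", "known", "first", "only" and "open" are said of these compounds alone.

Working notes on the series. Of the compounds shown here, three have been measured so far, all built on the shared core seen in compound 1 `ClCc1ccc(Cn2cnc3c(Cl)ncnc32)cc1`. In a functional assay on CAKI-1 cells (Homo sapiens) for cytotoxicity, read by sulforhodamine B assay, with a stated time of 48 h (on this read-out higher numbers stand for weaker inhibition of growth and lower numbers for stronger inhibition of growth), compound 1 gives 260 nM, the lowest number of the three. Compound 2 `ClCc1cccc(Cn2cnc3ncnc(Cl)c32)c1` gives 2130 nM in this assay, and compound 3 `ClCc1cccc(Cn2cnc3c(Cl)nc(Cl)nc32)c1` gives 2230 nM; both of these numbers stand above that of compound 1 by a margin beyond the scatter. Compound 2 and compound 3 differ from one another only by an added chloro group on the core, and their two numbers lie within the scatter of each other, so that pair shows no effect of the extra chloro group one way or the other.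

Compound 4 `ClCc1ccc(Cn2cnc3c(Cl)nc(Cl)nc32)cc1` has not yet been measured. It differs from compound 1 by chloro in place of hydrogen on an aromatic carbon. Within the data shown here, no measured pair maps this exact step from compound 1, but the values of compound 2 and compound 3 are the closest guide and show no shift. The step of a 1.3-fold higher number from compound 1 to compound 4 (0.13 log units; within the scatter) is therefore expected to be small, with no clear direction beyond the scatter. Compound 4 is expected to give about 350 nM in this assay, within a range from 120 nM to 1100 nM.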

Compound 4, concentration for 50% growth inhibition: 9120 nM
Compound 4: the middle estimate sits 26-fold (1.42 log units) below what was measured; the measured number lies above the stated range.
By their numbers in this assay, from the lowest: compound 1; then compounds 2 and 3 (each within the scatter of the next); then compound 4.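

Chloro in place of hydrogen on this aromatic carbon, between two ring nitrogen atoms, proves far from neutral on the core of compound 1: in this assay the change gives a 35-fold higher number from compound 1 to compound 4 (1.55 log units; beyond the scatter) and so a large loss of growth inhibition. Among these compounds, this is the first pair that differs in one place, and it shows that this single position can move the read-out strongly, with compound 4 now standing at the weak end of the series, which the earlier compounds could not show. Among the compounds shown here, nothing measured so far bears on why a single chloro group at this carbon has so large an effect.

Still open, as far as these compounds go, is whether the loss belongs to chloro itself or to any group larger than hydrogen on this carbon, a question that an amine, a methoxy group or a fluoro group at the same place would address. Also open is how far the step depends on the rest of compound 1, since the compounds shown give only this one pair for the change.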